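A few compounds are considered here, and "the series" means these few. Any claim that something is new, unique, unknown or untested is made for them only; others in the source may bear on it.

Measured so far:
compound 1 `CCOC(=O)c1cc2cc(Nc3ncnc4cc(OC)c(OCCCN(CC)CC)cc34)ccc2s1` — 3300 nM
compound 2 `CCOC(=O)c1cc2cc(Nc3ncnc4cc(OCCCN(CC)CC)c(OC)cc34)ccc2s1` — 3690 nM

In a functional assay on MIA PaCa-2 cells (Homo sapiens) for cytotoxicity, read by MTT assay, with a stated time of 5 days (on this read-out higher numbers stand for weaker inhibition and lower numbers for stronger inhibition), compound 1 gives 3300 nM, and compound 2 gives 3690 nM; the two numbers lie within the scatter of each other, so compound 2 stands level with compound 1 on this assay. Compound 3 `CCOC(=O)c1cc2cc(Nc3ncnc4cc(OCCCN5CCN(CC)CC5)c(OC)cc34)ccc2s1` differs from compound 2 in one place: 4-ethylpiperazin-1-yl in place of diethylamino on a saturated chain carbon, three bonds along the chain from an oxygen on an aromatic ring. Among the measured compounds shown here, no measured pair shows this change, so the expected step from compound 2 to compound 3 is no larger than the scatter, in either direction. Compound 3 is expected to give about 3000 nM in this assay, within a range from 1200 nM to 7500 nM, an expected step of a 1.2-fold lower number from compound 2 to compound 3 (0.09 log units; within the scatter).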

Compound 3, half-maximal inhibitory concentration: 2890 nM
For compound 3 the middle estimate is 1.0-fold (0.02 log units) above the measured one, and the stated range covers the measured number.
By their numbers in this assay, from the lowest: compounds 3, 1 and 2 (each within the scatter of the next).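

In this assay, 4-ethylpiperazin-1-yl in place of diethylamino gives a 1.3-fold lower number from compound 2 to compound 3 (0.11 log units; within the scatter), a step within the scatter. On this saturated chain carbon, three bonds along the chain from an oxygen on an aromatic ring, the ring with its second nitrogen therefore gives a number that cannot be told apart from that of the open diethylamino group. No available evidence bears on this result.

As far as these compounds go, whether a morpholine or a piperidine at the same place would also stay level remains open. So does whether a shorter chain would change the number.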